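The compounds below may be only part of what the source reports. "The series", "measured", "known", "first", "only" and "open" are said of these compounds alone.

In an ADME assay on HepG2 2.2.15 cells (Homo sapiens) for cytotoxicity (a higher number here means that more compound is tolerated, a lower number that less compound is tolerated), three compounds sharing one core have been measured. Compound 1 `O=C(OCCc1c(-c2ccccc2Cl)c2cc(Cl)ccc2[nH]c1=O)C1CCCC1` gives 46000 nM, compound 2 `O=C(CCC1CCCCC1)OCCc1c(-c2ccccc2Cl)c2cc(Cl)ccc2[nH]c1=O` gives 160000 nM, and compound 3 `O=C(OCCc1c(-c2ccccc2Cl)c2cc(Cl)ccc2[nH]c1=O)c1ccc([N+](=O)[O-])cc1` gives 1600000 nM, the highest of the three numbers. Compound 4 `O=C(CN1C(=O)c2ccccc2C1=O)OCCc1c(-c2ccccc2Cl)c2cc(Cl)ccc2[nH]c1=O` is still unmeasured. Its difference from compound 3 is a group of 12 heavy atoms (9 carbon, 1 nitrogen, 2 oxygen; one five-membered non-aromatic ring with 1 hetero atom, one six-membered aromatic ring of carbon only) in place of a group of 9 heavy atoms (6 carbon, 1 nitrogen, 2 oxygen; one six-membered aromatic ring of carbon only), on a carbonyl carbon. The measured steps all concern this same place on a carbonyl carbon. They show a 3.5-fold higher number from compound 1 to compound 2 (0.54 log units; beyond the scatter), a 35-fold higher number from compound 1 to compound 3 (1.54 log units; beyond the scatter) and a 10-fold higher number from compound 2 to compound 3 (1.00 log units; beyond the scatter). Among the measured compounds shown here, the entering group keeps a six-membered aromatic ring of carbon only, as 4-nitrophenyl does, but it adds a five-membered non-aromatic ring that no measured compound carries. With so few compounds, the evidence is thin. Compound 3 stands at the top of this small set, with a 10-fold higher number from compound 2 to compound 3 (1.00 log units; beyond the scatter) separating it from its nearest neighbour, so a new group is expected to land lower rather than higher. The expected change is a 5.3-fold lower number from compound 3 to compound 4 (0.73 log units; beyond the scatter). For compound 4 the estimated value is 300000 nM, with an expected range from 60000 nM to 1200000 nM.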

Compound 4, half-maximal cytotoxic concentration: 960000 nM
For compound 4 the middle estimate is 3.2-fold (0.51 log units) below the measured one; low and high end bracket the measured number.
By their numbers in this assay, from the lowest: compound 1; then compound 2; then compounds 4 and 3 (each within the scatter of the next).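

In this assay, swapping 4-nitrophenyl on the carbonyl carbon for the larger group with the added five-membered ring gives a step within the usual scatter (a 1.7-fold lower number from compound 3 to compound 4 (0.22 log units; within the scatter)), so the high number of compound 3 is not unique to 4-nitrophenyl. Among these four compounds alone, both groups with a six-membered aromatic ring of carbon only stand clear of the two groups with saturated carbon rings, and none goes against this (a 6.0-fold higher number from compound 2 to compound 4 (0.78 log units; beyond the scatter); a 21-fold higher number from compound 1 to compound 4 (1.32 log units; beyond the scatter)). Nothing available explains why these groups give such numbers.

Going by these compounds, it remains open whether a plain phenyl group, without the nitro group, would reach the same level. A piperidine ring in this place would show whether a saturated ring containing nitrogen behaves like the saturated carbon rings.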